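Dimethylamino in place of bromo on the shared core

The compounds below may be only part of what the source reports. "The series", "measured", "known", "first", "only" and "open" are said of these compounds alone.

In a functional assay for inhibition, with Homo sapiens as the target (a higher number here means a weaker inhibitor, a lower number a stronger inhibitor), compound 1 `O=C(/C=C/c1ccccc1)c1ccccc1OCc1ccccc1` gives 2230 nM and compound 2 `O=C(/C=C/c1ccccc1)c1ccccc1[N+](=O)[O-]` gives 1520 nM while compound 3 `O=C(/C=C/c1ccccc1)c1ccccc1Br` gives 1660 nM on the same read-out. Compound 3 stands within the scatter of both others, with a 1.1-fold higher number from compound 2 to compound 3 (0.04 log units; within the scatter) and a 1.3-fold lower number from compound 1 to compound 3 (0.13 log units; within the scatter) as its two steps.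

The change to compound 4 `CN(C)c1ccccc1C(=O)/C=C/c1ccccc1` puts dimethylamino in place of bromo on an aromatic carbon, ortho to a large group. For the measured compounds named here, the count of that change reads dimethylamino in place of bromo on an aromatic carbon and no measured compound carries dimethylamino.

The third measured exchange of groups is a 1.5-fold lower number from compound 1 to compound 2 (0.17 log units; within the scatter) and, like the other two, it stays within the scatter. These three steps show no size or direction to carry over, so no step beyond the scatter is expected in this assay and neither direction is favoured. From the compounds shown here alone, the range stays wide, as dimethylamino is untested.

The expected step is a 1.1-fold higher number from compound 3 to compound 4 (0.04 log units; within the scatter) on this reading. For compound 4 the estimated value is 1800 nM with an expected range from 800 nM to 4000 nM for now.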

Compound 4, half-maximal inhibitory concentration: 1770 nM
The estimate for compound 4 lay 1.0-fold (0.01 log units) above the measured number; low and high end bracket the measured number.
By their numbers in this assay, from the lowest: compounds 2, 3, 4 and 1 (each within the scatter of the next).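

In this assay, dimethylamino on an aromatic carbon ortho to a large group is the fourth group at this position, and its steps all stay within the scatter: a 1.1-fold higher number from compound 3 to compound 4 (0.03 log units; within the scatter), a 1.2-fold higher number from compound 2 to compound 4 (0.07 log units; within the scatter) and a 1.3-fold lower number from compound 1 to compound 4 (0.10 log units; within the scatter). Replacing bromo, 1 heavy atom, with dimethylamino, 3 heavy atoms with nitrogen and a hydrogen-bond acceptor, therefore gives no separation from bromo, and the nitro and benzyloxy comparisons give none either. No supporting measurement is available to interpret this result.

The compounds shown leave open whether any group at this position can produce a step beyond the scatter, for example a carboxylic acid or a primary amine. They also leave open whether a longer chain on the same carbon would stay within the scatter of these four compounds.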